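The source may hold more compounds than are shown below. What is called first, only, known or untested is meant among the compounds shown, and "the series" means these compounds.

Three compounds share one core, and compound 1 `NS(=O)(=O)Oc1ccc2c(c1)CN(C(=O)c1ccc(N(Cc3ccccc3)Cc3ccco3)cc1)CC2` gives 90.8% in an assay on HEK293 cells for inhibition of Steryl-sulfatase (Homo sapiens), tested at 0.1 uM; on this read-out lower numbers stand for a weaker effect and higher numbers for a stronger effect at the one concentration tested. Compound 2 `CCN(Cc1ccccn1)c1ccc(C(=O)N2CCc3ccc(OS(N)(=O)=O)cc3C2)cc1` gives 42.5% in this assay, while compound 3 `CN(CCN1CCCCC1)c1ccc(C(=O)N2CCc3ccc(OS(N)(=O)=O)cc3C2)cc1` gives 0.3%, the lowest of the three numbers. Going by the values given here, the single one-place step among them, a number 42.2 percentage points lower from compound 2 to compound 3 (beyond the scatter), shows how far this assay moves when the amino group on the aromatic carbon is exchanged. Compound 4 `CCN(Cc1ccccc1)c1ccc(C(=O)N2CCc3ccc(OS(N)(=O)=O)cc3C2)cc1` carries benzyl(ethyl)amino in place of methyl(2-(piperidin-1-yl)ethyl)amino on an aromatic carbon. Because compound 2, with its own arylmethyl on that nitrogen, stands at 42.5%, and compound 1, with a benzyl there, at 90.8%, a large rise in this assay is expected, estimated as a number 59.7 percentage points higher from compound 3 to compound 4 (beyond the scatter). Compound 4 is therefore expected to give about 60%, within 25% to 90%.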

Compound 4, a percentage reported as inhibition, at one concentration (the size of the read-out at that concentration, not a potency): 66.9%
Estimate against measurement, compound 4: 6.9 percentage points below, and the stated range covers the measured number.
By their numbers in this assay, from the lowest: compound 3; then compound 2; then compound 4; then compound 1.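

In this assay, the same count of heavy atoms at this place, with benzyl(ethyl)amino entering, gives a number 66.6 percentage points higher from compound 3 to compound 4 (beyond the scatter). Both groups on the nitrogen count: phenyl in place of pyridin-2-yl gives a number 24.4 percentage points higher from compound 2 to compound 4 (beyond the scatter), and methyl in place of furan-2-yl gives a number 23.9 percentage points lower from compound 1 to compound 4 (beyond the scatter). Nothing available accounts for these steps. Going by these compounds, it remains open whether a thiophen-2-yl in place of the furan-2-yl of compound 1 would hold its number, and what a chlorine on the phenyl ring of the benzyl would do.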